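This account rests on a few compounds, and the source may have more. Where it says the series, first, only, none or still open, it means among the compounds named here.

Working notes on the series. Three compounds have numbers in an ADME assay on the whole organism for pharmacokinetics, with Rattus norvegicus as the target, read by LC-MS, at a dose of 10 mg/kg by the oral route; a lower number here means less compound in the circulation, a higher number more compound in the circulation at the dose given. Compound 1 `CCN1C(=O)N[C@@](CN2Cc3ccc(OC)cc3C2=O)(c2cc3ncccc3o2)C1=O` gives 378 ng.h/mL in this assay. For the measured compounds named here, compound 2 `COCCOCCOCCN1C(=O)N[C@@](CN2Cc3ccc(OC)cc3C2=O)(c2cc3ncccc3o2)C1=O` gives 10.8 ng.h/mL; the only single-point step among the measured compounds is a 35-fold lower number from compound 1 to compound 2 (1.54 log units; beyond the scatter), a change on the chain carried by the imide nitrogen, not on the aromatic part. Compound 3 `CCN1CCN(c2ccc3oc([C@]4(CN5Cc6ccc(OC)c(F)c6C5=O)NC(=O)N(COC(=O)C(C)(C)C)C4=O)cc3n2)CC1` gives 12700 ng.h/mL, the highest of the three numbers, with compound 1 nearest and compound 2 furthest, both gaps beyond the scatter.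

Compound 4 `COc1ccc2c(c1F)C(=O)N(C[C@@]1(c3cc4nc(-c5cn[nH]c5)ccc4o3)NC(=O)N(COC(=O)C(C)(C)C)C1=O)C2` is not yet measured. It differs from compound 3 in one place: 1H-pyrazol-4-yl in place of 4-ethylpiperazin-1-yl on an aromatic carbon, on an aromatic carbon of a six-membered aromatic ring with one nitrogen, next to the ring nitrogen. Going by the values given here, no measured step in this assay touches this position or either of these two groups; the step from compound 1 to compound 2 concerns a different site and gives no direct guide. The expectation for compound 4 therefore rests on compound 3 alone, with a wide range and no firm direction, and the estimated step is a 4.2-fold lower number from compound 3 to compound 4 (0.63 log units; beyond the scatter). The estimated value for compound 4 in this assay is 3000 ng.h/mL, expected to fall between 400 ng.h/mL and 15000 ng.h/mL.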

Compound 4, area under the concentration-time curve: 177 ng.h/mL
Estimate against measurement, compound 4: 17-fold (1.23 log units) above; measured number below the stated range.
By their numbers in this assay, from the lowest: compound 2; then compound 4; then compound 1; then compound 3.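

In this assay, the group on the aromatic carbon next to the ring nitrogen has a large influence on the number: 1H-pyrazol-4-yl in place of 4-ethylpiperazin-1-yl gives a 72-fold lower number from compound 3 to compound 4 (1.86 log units; beyond the scatter). For the compounds shown here, the only earlier step lay on the chain carried by the imide nitrogen, so this is the first sign that a change on the aromatic part can also move the number beyond the scatter. The change swaps a six-membered non-aromatic ring for a five-membered aromatic ring and goes from 0 to 1 hydrogen-bond donor, but no evidence at hand separates these differences or accounts for the step.

Going by these compounds alone, with only two groups at this position, it remains open whether the number follows the ring, the ethyl on the piperazine or the pyrazole hydrogen on nitrogen; morpholin-4-yl, 4-methylpiperazin-1-yl and 1-methyl-1H-pyrazol-4-yl would each bear on that question. As far as these compounds go, it also remains open whether a step of this size would recur with a plain ethyl on the imide nitrogen in place of the chain shared by compound 3 and compound 4.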